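This account rests on a few compounds, and the source may have more. Where it says the series, first, only, none or still open, it means among the compounds named here.

Compound 1 `Cc1ccc(Nc2ncc3c(n2)N(C)C(=O)N(c2cc(NC(=O)c4cccc(C(F)(F)F)c4)ccc2C)C3)cc1` gives 18 nM in a functional assay on K562 cells (Homo sapiens) for antiproliferative activity, read by CellTiter-Glo and CCK-8 assay, with a stated time of 72 h; a lower number here means a stronger inhibitor of growth, a higher number a weaker inhibitor of growth. Compound 2 `CNc1cc(Nc2ncc3c(n2)N(C)C(=O)N(c2cc(NC(=O)c4cccc(C(F)(F)F)c4)ccc2C)C3)ccc1C` gives 19 nM in this assay. Compound 3 `Cc1ccc(Nc2ncc3c(n2)N(C)C(=O)N(c2cc(NC(=O)c4cccc(C(F)(F)F)c4)ccc2C)C3)cc1N` gives 3 nM in this assay.

Compound 3 stands lowest of these three numbers. For the measured compounds named here, the step of a 6.0-fold lower number from compound 1 to compound 3 (0.78 log units; beyond the scatter) and the step of a 6.3-fold lower number from compound 2 to compound 3 (0.80 log units; beyond the scatter) both lie beyond the scatter, whereas the step of a 1.1-fold higher number from compound 1 to compound 2 (0.02 log units; within the scatter) stays within it, so the amino group on the outer ring is the one change among the measured compounds that clearly moves the number.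

Compound 4 `Cc1ccc(Oc2ncc3c(n2)N(C)C(=O)N(c2cc(NC(=O)c4cccc(C(F)(F)F)c4)ccc2C)C3)cc1N` differs from compound 3 in one place: 3-amino-4-methylphenoxy in place of (3-amino-4-methylphenyl)amino on an aromatic carbon. Going by the values given here, none of the measured steps touches this part of the structure; all three vary the group on the outer ring while the link to the shared core stays the same. The counted difference is the loss of one hydrogen-bond donor at the link. Among the compounds with values here, with no measured step bearing on this change, the expectation rests on that counted loss alone and is uncertain. A somewhat weaker inhibitor of growth is expected, by a step of a 13-fold higher number from compound 3 to compound 4 (1.12 log units; beyond the scatter). Compound 4 is therefore estimated at 40 nM, with a range from 8 nM to 300 nM.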

Compound 4, concentration for 50% growth inhibition: 13 nM
Compound 4: the middle estimate sits 3.1-fold (0.49 log units) above what was measured; measured number inside the range.
By their numbers in this assay, from the lowest: compound 3; then compounds 4, 1 and 2 (each within the scatter of the next).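

Changing the link itself also moves the number: in this assay, 3-amino-4-methylphenoxy in place of (3-amino-4-methylphenyl)amino, on the aromatic carbon between two ring nitrogen atoms, gives a 4.3-fold higher number from compound 3 to compound 4 (0.64 log units; beyond the scatter). For the compounds shown here, the earlier compounds varied only the outer ring, so this is the first sign that the link matters as well as the amino group on that ring. With the oxygen link, the amino-bearing compound no longer stands apart from the two compounds that lack that amino group, as shown by a 1.4-fold lower number from compound 1 to compound 4 (0.14 log units; within the scatter) and a 1.5-fold lower number from compound 2 to compound 4 (0.16 log units; within the scatter), so among these compounds the amino group alone does not give the low number of compound 3, and nothing available here explains this result.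

As far as these compounds go, it remains open whether a sulfur atom or a methylene group at the link would give a number closer to that of compound 3 or of compound 4. From the compounds shown here alone, it is also open whether the oxygen-linked series would respond to a hydroxyl or a methylamino group on the outer ring as the nitrogen-linked compounds respond to their groups.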